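Cytotoxicity notes: benzoxazole in place of benzothiophene

The source may hold more compounds than are shown below. What is called first, only, known or untested is meant among the compounds shown, and "the series" means these compounds.

Measured so far:
compound 1 `Nc1nc(Cl)c(-c2cccs2)c(N[C@@H]2C[C@H](CO)[C@@H](O)[C@H]2O)n1` — > 25000 nM (a limit)
compound 2 `Nc1nc(Cl)c(-c2cc3ccccc3s2)c(N[C@@H]2C[C@H](CO)[C@@H](O)[C@H]2O)n1` — > 25000 nM (a limit)

In an ADME assay on cells (Homo sapiens) for cytotoxicity, read by polymerase chain reaction, with a stated time of 3 days (a higher number here means that more compound is tolerated, a lower number that less compound is tolerated), compound 1 gives > 25000 nM, which is a limit of the assay and not a number. Compound 2 gives > 25000 nM in this assay, again a limit. The step that the two limits leave unreadable from compound 1 to compound 2 therefore cannot be read. Among the measured compounds shown here, compound 2 thus stands only at a limit, and the one further value shown is a limit as well, both sitting at the limit of > 25000 nM in this assay, at which 2 of the 2 values shown sit.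

Compound 3 `Nc1nc(Cl)c(-c2nc3ccccc3o2)c(N[C@@H]2C[C@H](CO)[C@@H](O)[C@H]2O)n1` differs from compound 2 by 1,3-benzoxazol-2-yl in place of 1-benzothiophen-2-yl on an aromatic carbon. For the measured compounds named here, the single measured step, from compound 1 to compound 2, bears on a change at the same position but gives no readable size, so no step beyond the scatter can be read from it. Compound 3 is expected to give 30000 nM in this assay, within 12000 nM to 80000 nM, most probably again reported as a limit. The expected step is a step that the limit leaves unreadable from compound 2 to compound 3.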

Compound 3, half-maximal cytotoxic concentration: 12000 nM
For compound 3 the middle estimate is 2.5-fold (0.40 log units) above the measured one; low and high end bracket the measured number.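

At this place, ortho to a chloro group, the group on the aromatic carbon does affect the result in this assay: 1,3-benzoxazol-2-yl gives an at least 2.0-fold lower number from compound 2 to compound 3 (0.31 log units; beyond the scatter), and set against thiophen-2-yl it gives an at least 2.0-fold lower number from compound 1 to compound 3 (0.31 log units; beyond the scatter). Both steps are minimum sizes, as neither compound 1 nor compound 2 has a number to measure from: the limit of > 25000 nM in this assay, at which 2 of the 3 values shown sit. Compound 2 and compound 3 share a six-membered aromatic ring of carbon only, so the step between them goes with the change in the five-membered aromatic ring, where sulfur gives way to nitrogen and oxygen.

From the compounds shown here alone, the true size of both steps remains open, as does whether the nitrogen or the oxygen of the entering ring goes with the lower number. A 1,3-oxazol-2-yl or an amine at this place would test how far the change extends.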